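Moving the hydroxyl on a weak pyridine inhibitor

The source may report more compounds than this note shows. Statements on the series, on what has been measured and on what is new or still open speak of the compounds shown alone.

Compound 1 `Oc1ccc(-c2cc(-c3cccc(F)c3)cc(-c3cccc(O)c3)n2)cc1` gives 2700 nM in a functional assay on DU-145 cells (Homo sapiens) for inhibition (a higher number here means a weaker inhibitor, a lower number a stronger inhibitor), and compound 2 `Oc1ccc(-c2cc(-c3ccc(F)cc3)cc(-c3ccc(O)cc3)n2)cc1` gives 6030 nM there. For compound 3 `Oc1ccc(-c2cc(-c3ccc(C(F)(F)F)cc3)cc(-c3cccc(O)c3)n2)cc1` this assay gives > 50000 nM, which is a limit and not a number. Going by the values given here, the only measured step to it, an at least 18-fold higher number from compound 1 to compound 3 (1.26 log units; beyond the scatter), is large, and compound 3 sits at the limit of > 50000 nM in this assay, at which 1 of the 3 values shown sits. Compound 4 `Oc1ccc(-c2cc(-c3ccc(C(F)(F)F)cc3)cc(-c3ccc(O)cc3)n2)cc1` differs from compound 3 by 4-hydroxyphenyl in place of 3-hydroxyphenyl on an aromatic carbon. Among the compounds with values here, no measured step isolates this change; compounds 1 and 2 differ in two places, so their values can only be set side by side. Compound 4 is therefore expected to stay near the limit, with a step that the limit leaves unreadable from compound 3 to compound 4 meaning no step beyond the scatter in this assay. The estimate for compound 4 is 80000 nM, ranging from 30000 nM to 250000 nM.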

Compound 4, half-maximal inhibitory concentration: > 50000 nM
Compound 4 ended at the assay's limit; the forecaster's own chance of this, stated with the estimate: 75%; the middle value does not contradict the limit.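

With 4-hydroxyphenyl on the aromatic carbon next to the ring nitrogen, trifluoromethyl in place of fluoro weakens inhibition in this assay, with an at least 8.2-fold higher number from compound 2 to compound 4 (0.91 log units; beyond the scatter). The loss seen with compound 3 therefore also appears in a compound carrying the other hydroxyphenyl group. The step from compound 3 to compound 4 cannot be read, as both values are limits: the limit of > 50000 nM in this assay, at which 2 of the 4 values shown sit.

From the compounds shown here alone, whether moving the hydroxyl matters at all with a trifluoromethyl group present stays open. So does what an amine or a carboxylic acid in place of that hydroxyl would give in this assay.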